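This account rests on a few compounds, and the source may have more. Where it says the series, first, only, none or still open, it means among the compounds named here.

Notes on the series. The compounds share one core and differ only in the group on a saturated chain carbon bound to an oxygen on a saturated carbon. In a functional assay on HEK293 cells for agonist activity at G-protein coupled receptor 39 (Homo sapiens), read by scintillation proximity assay and inositol phosphate accumulation, with a stated time of 75 min, in the presence of a further agent that is not named here (a higher number here means that more compound is needed for the effect, a lower number that less compound is needed), compound 1 `Cc1nn(-c2ncnc3nc[nH]c23)c2c1C(OCc1ccc(C(C)C)cc1)CC(=O)N2` gives 5 nM. Compound 2 `Cc1nn(-c2ncnc3nc[nH]c23)c2c1C(OCCc1ccccc1)CC(=O)N2` gives 3 nM in this assay, and compound 3 `COc1ccc(CCOC2CC(=O)Nc3c2c(C)nn3-c2ncnc3nc[nH]c23)cc1` gives 2 nM. Compound 3 holds the lowest of the measured values; its gap to compound 2 is within the scatter, so no order between those two is claimed, whereas against compound 1 the step is beyond the scatter, though modest: a 2.5-fold lower number from compound 1 to compound 3 (0.40 log units; beyond the scatter). The remaining steps are small: a 1.7-fold lower number from compound 1 to compound 2 (0.22 log units; within the scatter) and a 1.5-fold lower number from compound 2 to compound 3 (0.18 log units; within the scatter).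

Compound 4 `Cc1nn(-c2ncnc3nc[nH]c23)c2c1C(OCc1cc(F)cc3c1OCOC3)CC(=O)N2` is not yet measured. Relative to compound 3 the change is a group of 11 heavy atoms (8 carbon, 2 oxygen, 1 fluorine; one six-membered non-aromatic ring with 2 hetero atoms, one six-membered aromatic ring of carbon only) in place of a group of 9 heavy atoms (8 carbon, 1 oxygen; one six-membered aromatic ring of carbon only), on a saturated chain carbon bound to an oxygen on a saturated carbon. Within the data shown here, the steps that bear on it are the ones altering the same group: a 1.7-fold lower number from compound 1 to compound 2 (0.22 log units; within the scatter) and a 2.5-fold lower number from compound 1 to compound 3 (0.40 log units; beyond the scatter), one within the scatter and one only just beyond it, plus the methoxy-for-hydrogen step a 1.5-fold lower number from compound 2 to compound 3 (0.18 log units; within the scatter), also within the scatter. Across these variations this assay has moved little, so no step beyond the scatter is expected here. The expected step is therefore a 1.5-fold higher number from compound 3 to compound 4 (0.18 log units; within the scatter). The estimate for compound 4 in this assay is 3 nM, with a range from 1 nM to 10 nM.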

Compound 4, half-maximal effective concentration: 1.5 nM
Beside the measured number, compound 4's estimate is 2.0-fold (0.30 log units) above it; measured number inside the range.
By their numbers in this assay, from the lowest: compounds 4, 3, 2 and 1 (each within the scatter of the next, the first and the last beyond it).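

In this assay, the place on a saturated chain carbon bound to an oxygen on a saturated carbon accepts a group of 11 heavy atoms, with fluorine and a six-membered non-aromatic ring with 2 hetero atoms, without any step beyond the scatter against the simpler groups: a 1.3-fold lower number from compound 3 to compound 4 (0.12 log units; within the scatter) and a 2.0-fold lower number from compound 2 to compound 4 (0.30 log units; within the scatter), so no order among compound 2, compound 3 and compound 4 is claimed. The new step beyond the scatter, a 3.3-fold lower number from compound 1 to compound 4 (0.52 log units; beyond the scatter), is modest and joins a 2.5-fold lower number from compound 1 to compound 3 (0.40 log units; beyond the scatter), which sets the 4-isopropylphenyl compound apart from two of the three other compounds, while compound 2 goes against this by staying within the scatter of it. No measured property is at hand that bears on these numbers.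

On these data alone, the fluorine and the non-aromatic ring enter together in compound 4, so their separate contributions to the value remain open. Also open is whether this place keeps such low numbers with an amine, a carboxylic acid or a longer chain in the group, since every group shown ends in a six-membered aromatic ring of carbon only.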